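This account rests on a few compounds, and the source may have more. Where it says the series, first, only, none or still open, it means among the compounds named here.

In a functional assay on Caco-2 cells (Homo sapiens) for inhibition, read by MTT assay, with a stated time of 48 h, tested at 10 uM (a higher number here means more inhibition of growth at the concentration tested, a lower number less inhibition of growth), compound 1 `Cc1oc2c([C@H]3CCN(C)C[C@H]3O)c(O)cc(O)c2c(=O)c1C(O)c1ccc(Cl)cc1` gives 3% and compound 2 `Cc1oc2c([C@H]3CCN(C)C[C@H]3O)c(O)cc(O)c2c(=O)c1C(O)c1csc([N+](=O)[O-])c1` gives 3% while compound 3 `COc1ccc(C(O)c2c(C)oc3c([C@H]4CCN(C)C[C@H]4O)c(O)cc(O)c3c2=O)cc1Br` gives 0% and so stands within the scatter of both others, with all three values small. Compound 4 `Cc1oc2c([C@H]3CCN(C)C[C@H]3O)c(O)cc(O)c2c(=O)c1C(O)c1cc(F)cc(F)c1` differs from compound 3 by one exchange (3,5-difluorophenyl in place of 3-bromo-4-methoxyphenyl on a saturated chain carbon bound to an aromatic carbon and an oxygen on a saturated carbon) at the same place where the measured compounds differ from one another. Three measured steps at that place bear on it, namely no change at the digits printed from compound 1 to compound 2 (within the scatter) together with a number 3 percentage points lower from compound 1 to compound 3 (within the scatter) and a number 3 percentage points lower from compound 2 to compound 3 (within the scatter) and none of them leaves the scatter. Among the measured compounds shown here, no measured compound carries a 3,5-difluorophenyl group, so the expectation rests on these three neighbours alone. No step beyond the scatter is expected in this assay for this exchange, in either direction. The expected step is a number 3 percentage points higher from compound 3 to compound 4 (within the scatter) and it is estimated to stay within the scatter. Compound 4 is estimated at 3% with 0% to 12% as the expected range.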

Compound 4, percent growth inhibition at one concentration: 10%
Compound 4: the middle estimate sits 7 percentage points below what was measured; the range from low to high includes it.
By their numbers in this assay, from the lowest: compounds 3, 1, 2 and 4 (each within the scatter of the next).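

In this assay, among the compounds shown here, the exchange on a saturated chain carbon bound to an aromatic carbon and an oxygen on a saturated carbon gives a number 10 percentage points higher from compound 3 to compound 4 (within the scatter) and the other two comparisons give a number 7 percentage points higher from compound 2 to compound 4 (within the scatter) and a number 7 percentage points higher from compound 1 to compound 4 (within the scatter) with no step leaving the scatter. The 3,5-difluorophenyl group therefore joins 4-chlorophenyl, 5-nitrothiophen-3-yl and 3-bromo-4-methoxyphenyl as a fourth group at this place, and this assay separates none of the four from another. No measured evidence explains the values at this place.

Still open, from the compounds shown here alone, is whether an aminomethyl group, a carboxylic acid or a longer alkyl chain in place of the aromatic ring would give a step beyond the scatter. Also open, going by these compounds, is whether replacing the hydroxy group on that carbon with an amine would do so.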